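From a Branched Alkene to a Cyclohexyl Ring

The source may hold more compounds than are shown below. What is called first, only, known or untested is meant among the compounds shown, and "the series" means these compounds.

Compound 1 `CC(C)=C(C)C#Cc1ccc(CCC(=O)O)cc1` is the starting point. In a functional assay on 1321-N1 cells for agonist activity at Free fatty acid receptor 1 (Homo sapiens), read by calcium flux, with a stated time of 0.4 s (on this read-out higher numbers stand for larger maximal responses and lower numbers for smaller maximal responses), compound 1 gives 105%, and the two other measured values differ from it only within the scatter. Compound 2 `C/C=C(\C)C#Cc1ccc(CCC(=O)O)c(F)c1` gives 97% in this assay, and compound 3 `C/C=C/C#Cc1ccc(CCC(=O)O)c(F)c1` gives 97%. Going by the values given here, the only one-place step among the measured compounds, no change at the digits printed from compound 2 to compound 3 (within the scatter), exchanges one group on the triple-bonded carbon for another and leaves the maximal response where it was.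

Compound 4 `O=C(O)CCc1ccc(C#CC2CCCCC2)cc1` differs from compound 1 in a single place: cyclohexyl in place of 1,2-dimethylprop-1-en-1-yl on a triple-bonded carbon. Among the compounds with values here, no measured step turns an open-chain group into a saturated ring, so the step from compound 2 to compound 3 is the closest guide, and it shows that the group on the triple-bonded carbon could be altered without a shift beyond the scatter. The step of a number 5 percentage points lower from compound 1 to compound 4 (within the scatter) is therefore expected to stay within the scatter. Compound 4 is estimated to give 100% in this assay, within a range from 80% to 115%.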

Compound 4, largest response reached (reported as efficacy), in percent of the reference or control that the assay uses: 98%
For compound 4 the middle estimate is 2 percentage points above the measured one, and the stated range covers the measured number.
By their numbers in this assay, from the lowest: compounds 2, 3, 4 and 1 (each within the scatter of the next).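

Putting cyclohexyl in place of 1,2-dimethylprop-1-en-1-yl on a triple-bonded carbon gives a number 7 percentage points lower from compound 1 to compound 4 (within the scatter) in this assay. The earlier step only exchanged one open-chain group with a double bond for another, whereas this one removes the double bond outside aromatic rings and brings in a six-membered non-aromatic ring of carbon only, and the maximal response still stays within the scatter. For this pair, then, neither the open chain nor that double bond is needed to keep the maximal response, though no measured evidence is at hand to explain this.

Going by these compounds alone, the groups at this place so far contain carbon only, so it remains open whether a phenyl ring or a cyclohexyl ring carrying an amine would keep the maximal response of compound 1. The largest response also says nothing about how much of each compound is needed to reach it.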